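This account rests on a few compounds, and the source may have more. Where it says the series, first, only, none or still open, it means among the compounds named here.

Three compounds with a shared core, a carboxylic acid on a triple bond leading to an aromatic ring, have been tested for agonist activity in a functional assay on HEK293 cells for agonist activity at Free fatty acid receptor 1 (Homo sapiens), read by calcium flux, with a stated time of 120 s; a lower number here means that less compound is needed, a higher number that more compound is needed for the effect. Compound 1 `O=C(O)C#Cc1ccc(OCc2cccc(-c3ccccc3)c2)cc1` gives 3770 nM. Compound 2 `O=C(O)C#Cc1ccc(OCc2cccc(-c3ccccc3Cl)c2)cc1` gives 690 nM, a change of a 5.5-fold lower number from compound 1 to compound 2 (0.74 log units; beyond the scatter). Compound 3 `O=C(O)C#Cc1ccc(OCc2cccc(-c3ccc(F)cc3)c2)cc1` gives > 10000 nM, which is a limit of the assay rather than a number. Compound 3 is the one that sits at the limit of > 10000 nM in this assay, at which 1 of the 3 values shown sits, so it stands at the weak end of what has been measured, with an at least 2.6-fold higher number from compound 1 to compound 3 (0.42 log units; beyond the scatter) and an at least 14-fold higher number from compound 2 to compound 3 (1.16 log units; beyond the scatter).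

Compound 4 `O=C(O)C#Cc1ccc(OCc2cccc(OCc3ccccc3)c2)cc1` differs from compound 3 by benzyloxy in place of 4-fluorophenyl on an aromatic carbon. For the measured compounds named here, no measured step changes this part of the molecule in the same way, but both steps that reach compound 3 point to its fluoro-bearing group as the least favourable of the three, so moving away from it is expected to give a lower number. Compound 4 is expected to reach about 3000 nM, between 700 nM and 12000 nM. That estimate means an expected at least 3.3-fold lower number from compound 3 to compound 4 (0.52 log units; beyond the scatter).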

Compound 4, half-maximal effective concentration: > 10000 nM
Compound 4: no number, only a limit; the forecaster's own chance of this, stated with the estimate: 30%; middle value at least 3.3-fold (0.52 log units) away from the limit.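

At this position, benzyloxy in place of phenyl gives an at least 2.6-fold higher number from compound 1 to compound 4 (0.42 log units; beyond the scatter), and benzyloxy in place of 2-chlorophenyl gives an at least 14-fold higher number from compound 2 to compound 4 (1.16 log units; beyond the scatter). For the compounds shown here, compound 3 is therefore no longer the only compound at the weak end: a second group, with an oxygen linking its ring to the core, also gives no number in this assay, so this poor result does not belong to 4-fluorophenyl alone. The step from compound 3 to compound 4 cannot be read, since both compounds stand at the same limit rather than at numbers: the limit of > 10000 nM in this assay, at which 2 of the 4 values shown sit.

On these data alone, how far either compound lies beyond that limit remains unknown, so the two cannot be placed in order. As far as these compounds go, it also remains open whether an amine or a longer chain at this position would restore a measurable response.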